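Swapping Acetyl for Pyridin-2-ylmethyl on a Ring Nitrogen

The source may hold more compounds than are shown below. What is called first, only, known or untested is meant among the compounds shown, and "the series" means these compounds.

Measured so far:
compound 1, `CCCCNc1nc(N)nc2c1CCN(Cc1ccccc1)C2`, 0.4 uM
compound 2, `CCCCNc1nc(N)nc2c1CN(C(C)=O)CC2`, 0.5 uM
compound 3, `CCCCNc1nc(N)nc2c1CCN(S(C)(=O)=O)C2`, 0.8 uM

In an assay on HEK293 cells for agonist activity at Toll-like receptor 8 (Homo sapiens), read by a luciferase reporter, with a stated time of 6 h (on this read-out higher numbers stand for an effect only at larger amounts of compound and lower numbers for an effect already at smaller amounts), compound 2 gives 0.5 uM. Its number lies between those of compound 1 and compound 3, and all three lie within the usual scatter of one another, so none of them can be called more or less active than the others.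

Compound 4, `CCCCNc1nc(N)nc2c1CN(Cc1ccccn1)CC2`, is not yet measured. It differs from compound 2 in one place: (pyridin-2-yl)methyl in place of acetyl on an amine nitrogen in a ring.

Going by the values given here, only one measured step touches the same amine nitrogen in a ring: a 2.0-fold higher number from compound 1 to compound 3 (0.30 log units; within the scatter). There the group on that nitrogen was exchanged between benzyl and methylsulfonyl, groups as unlike each other as acetyl and (pyridin-2-yl)methyl, and the number hardly moved. Compound 1 carries benzyl, which resembles (pyridin-2-yl)methyl, and gives 0.4 uM. The step to compound 4 is therefore expected to be small, a 1.3-fold lower number from compound 2 to compound 4 (0.10 log units; within the scatter), in no direction beyond the scatter.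

Compound 4 is estimated at 0.4 uM, in the range 0.15 uM to 1 uM.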

Compound 4, minimum effective concentration: 0.07 uM
Beside the measured number, compound 4's estimate is 5.7-fold (0.76 log units) above it, and the stated range ends above it.
By their numbers in this assay, from the lowest: compound 4; then compounds 1, 2 and 3 (each within the scatter of the next).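

In this assay the amine nitrogen in the ring of this core turns out not to be indifferent to what it carries: (pyridin-2-yl)methyl in place of acetyl gives a 7.1-fold lower number from compound 2 to compound 4 (0.85 log units; beyond the scatter) and so lies beyond the scatter. The earlier step, a 2.0-fold higher number from compound 1 to compound 3 (0.30 log units; within the scatter), stayed within the scatter, but it was read on the core of compound 1, which differs from the core of compound 2, so a quiet step on one core did not predict the step on the other. Nothing available explains why this exchange moves the number.

Still open, going by these compounds, is whether the aromatic ring alone is enough on this core or whether its ring nitrogen also counts, which a plain benzyl group here would test. On these data alone, how (pyridin-4-yl)methyl or a longer 2-phenylethyl chain would read on the same nitrogen is also open.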